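The source may report more compounds than this note shows. Statements on the series, on what has been measured and on what is new or still open speak of the compounds shown alone.

Compound 1 `Nc1ccccc1NC(=O)c1ccc(NCC(=O)Nc2cccc([N+](=O)[O-])c2)cc1` was tested in a functional assay on U-251 cells (Homo sapiens) for inhibition, read by MTT assay, with a stated time of 2 days; a higher number here means that more compound is tolerated, a lower number that less compound is tolerated. In this assay compound 1 gives > 100000 nM, which is a limit of the measurement rather than a number. Compound 2 `Nc1ccccc1NC(=O)CCCNCC(=O)Nc1cc(Cl)ccc1Cl` was also tested; in this assay compound 2 gives > 100000 nM, again a limit. Both values sit at the limit of > 100000 nM in this assay, at which 2 of the 2 values shown sit. Compound 3 `Nc1ccccc1NC(=O)c1ccc(NCC(=O)Nc2ccc(Cl)cc2)cc1` differs from compound 1 in one place: 4-chlorophenyl in place of 3-nitrophenyl on an amide-type nitrogen. Going by the values given here, no measured pair isolates such a change, so no step beyond the scatter is expected in this assay. Compound 3 is expected to give 100000 nM, with a range from 40000 nM to 300000 nM. The step expected is a number no higher from compound 1 to compound 3 (the limit leaves the size open), essentially flat.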

Compound 3, concentration lethal to 50% of the cells: > 100000 nM
Compound 3 was reported as a limit; the forecaster's own chance of this, stated with the estimate: 80%; the middle value sits exactly at the limit.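

Compound 1 and compound 3 are both reported as limits rather than numbers, so no step can be read between them: the limit of > 100000 nM in this assay, at which 3 of the 3 values shown sit. The compounds shown leave open which structural change, if any, would give a readable number in this assay.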